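From Methyl to Methoxy on the Aromatic Ring

The source may hold more compounds than are shown below. What is called first, only, known or untested is meant among the compounds shown, and "the series" means these compounds.

Compound 1 `CC1=CC[C@@H]([C@@](C)(O)CCCC(C)(C)NC(=S)NN)CC1` was tested in a functional assay on OVCAR-3 cells (Homo sapiens) for cytotoxicity, read by sulforhodamine B assay; on this read-out higher numbers stand for lower toxicity in this test and lower numbers for higher toxicity in this test; its value there, > 100000 nM, is a limit of the assay rather than a number. Compound 2 `CC1=CC[C@@H]([C@@](C)(O)CCCC(C)(C)NC(=S)N/N=C\c2ccccc2)CC1` gives 43600 nM in this assay, and compound 3 `CC1=CC[C@@H]([C@@](C)(O)CCCC(C)(C)NC(=S)N/N=C\c2ccc(C)cc2)CC1` gives 45300 nM. Within the data shown here, of the two numbers, the one for compound 3 is the higher, but the gap to compound 2, a 1.0-fold higher number from compound 2 to compound 3 (0.02 log units; within the scatter), lies within the scatter. Compound 4 `COc1ccc(/C=N\NC(=S)NC(C)(C)CCC[C@](C)(O)[C@@H]2CC=C(C)CC2)cc1` differs from compound 3 by methoxy in place of methyl on an aromatic carbon. Among the measured compounds shown here, the only measured step at this aromatic carbon, a 1.0-fold higher number from compound 2 to compound 3 (0.02 log units; within the scatter), produced no change beyond the scatter. Swapping one small group for another there is therefore expected to leave the number essentially where it is, a step of a 1.0-fold lower number from compound 3 to compound 4 (0.00 log units; within the scatter). Compound 4 is estimated at 45000 nM, within the range 20000 nM to 100000 nM.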

Compound 4, concentration lethal to 50% of the cells: 46200 nM
Compound 4: middle estimate off by 1.0-fold (0.01 log units), on the low side; measured number inside the range.
By their numbers in this assay, from the lowest: compounds 2, 3 and 4 (each within the scatter of the next). At a limit, above all of these: compound 1.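

In this assay, methoxy at this ring carbon, para to a large group, gives no change beyond the scatter against either methyl or hydrogen: a 1.0-fold higher number from compound 3 to compound 4 (0.01 log units; within the scatter), and a 1.1-fold higher number from compound 2 to compound 4 (0.03 log units; within the scatter). Hydrogen, methyl and now an oxygen-linked group thus all give numbers within the scatter of one another in compounds 2, 3 and 4. Among these compounds, only the step that adds the whole aromatic group lies beyond the scatter, an at least 2.1-fold lower number from compound 1 to compound 4 (0.33 log units; beyond the scatter), and its size is only a bound set by a limit: the limit of > 100000 nM in this assay, at which 1 of the 4 values shown sits. As far as these compounds go, whether an amine or a carboxylic acid at this ring carbon would also leave the number in place remains open.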